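The source may report more compounds than this note shows. Statements on the series, on what has been measured and on what is new or still open speak of the compounds shown alone.

Working notes on the series in a functional assay on a cell-free system (plasma) for inhibition of thromboxane A2 receptor (Homo sapiens), read by turbidimetry; a higher number here means a weaker inhibitor, a lower number a stronger inhibitor. Within the data shown here, compound 3 `O=C(O)CC/C=C\C[C@H]1[C@H](F)CC[C@@H]1NS(=O)(=O)c1ccc(Cl)c(Cl)c1` gives 1700 nM, the highest of the three numbers measured so far. Nearest to it is compound 1 `O=C(O)CCC/C=C\C[C@H]1[C@H](F)CC[C@@H]1NS(=O)(=O)c1ccccc1`, which gives 1100 nM, within the scatter of compound 3; compound 2 `O=C(O)CC/C=C\C[C@H]1[C@H](F)CC[C@@H]1NS(=O)(=O)c1ccc(Cl)cc1` gives 210 nM, well beyond it. Among the measured compounds shown here, the only single-point step measured so far is an 8.1-fold higher number from compound 2 to compound 3 (0.91 log units; beyond the scatter), a chloro in place of hydrogen on an aromatic carbon.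

Compound 4 `O=C(O)CC/C=C\C[C@H]1[C@H](F)CC[C@@H]1NS(=O)(=O)c1ccccc1` is the next to be measured in this assay. It differs from compound 3 by phenyl in place of 3,4-dichlorophenyl on a sulfonyl sulfur. The step from compound 2 to compound 3 bears directly on this change, since one of its two parts simply undoes that step and would on its own return the number toward that of compound 2. For the measured compounds named here, the other part, removal of the chloro that compound 2 also carries, has no measured counterpart; compound 1, which carries phenyl but a different acid chain, gives 1100 nM, and no step is drawn between it and compound 4. A downward step is therefore expected, a 3.4-fold lower number from compound 3 to compound 4 (0.53 log units; beyond the scatter), with its size uncertain. Compound 4 is estimated at 500 nM, with a range from 150 nM to 1700 nM.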

Compound 4, half-maximal inhibitory concentration: 2000 nM
Estimate against measurement, compound 4: 4.0-fold (0.60 log units) below; the measured number lies above the stated range.
By their numbers in this assay, from the lowest: compound 2; then compounds 1, 3 and 4 (each within the scatter of the next).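

In this assay, phenyl and 3,4-dichlorophenyl on the sulfonyl sulfur cannot be told apart, with a 1.2-fold higher number from compound 3 to compound 4 (0.07 log units; within the scatter), while a 9.5-fold higher number from compound 2 to compound 4 (0.98 log units; beyond the scatter) sits alongside an 8.1-fold higher number from compound 2 to compound 3 (0.91 log units; beyond the scatter), so compound 2 stands apart from both and the number does not follow a steady trend with the chloro substituents across these three compounds. With phenyl on the sulfonyl sulfur, the change of acid chain also stays within the scatter, with a 1.8-fold higher number from compound 1 to compound 4 (0.26 log units; within the scatter), so the two chain lengths are not separated by this pair. Nothing available accounts for the separate position of compound 2.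

As far as these compounds go, whether a bromo, methyl or methoxy group on the aromatic carbon that carries the chloro in compound 2 would keep a number near that of compound 2 remains open. From the compounds shown here alone, it is also open whether the longer acid chain of compound 1 would be equally silent when paired with the aryl group of compound 2, since the chain comparison rests on phenyl alone.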